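Moving the trifluoromethyl group on the hydrazone aryl ring

This account rests on a few compounds, and the source may have more. Where it says the series, first, only, none or still open, it means among the compounds named here.

Measured compounds:
- compound 1 `CN(C(=O)NC(=O)c1ccc([N+](=O)[O-])cc1)c1nc(C(F)(F)F)c(C(=O)N/N=C/c2cccc(C(F)(F)F)c2)s1` gives 5.42 ug/mL in a functional assay on A549 cells (Homo sapiens) for inhibition, read by MTT assay, with a stated time of 72 h; a higher number here means a weaker inhibitor, a lower number a stronger inhibitor
- compound 2 `CN(C(=O)NC(=O)c1ccc(F)c(F)c1)c1nc(C(F)(F)F)c(C(=O)N/N=C/c2ccc([N+](=O)[O-])cc2)s1` gives 5.78 ug/mL in this assay
- compound 3 `CN(C(=O)NC(=O)c1ccc(F)c(F)c1)c1nc(C(F)(F)F)c(C(=O)N/N=C/c2ccc(C(F)(F)F)cc2)s1` gives 6.07 ug/mL in this assay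

Compound 3 has the highest of the three numbers, but it sits within the scatter of compound 2 and of compound 1, so the three cannot be told apart. Going by the values given here, the one single-point step seen so far, a 1.1-fold higher number from compound 2 to compound 3 (0.02 log units; within the scatter), concerns a different part of the molecule and stays within the scatter.

Compound 4 `CN(C(=O)NC(=O)c1ccc(F)c(F)c1)c1nc(C(F)(F)F)c(C(=O)N/N=C/c2cccc(C(F)(F)F)c2)s1` differs from compound 3 in one place: 3-(trifluoromethyl)phenyl in place of 4-(trifluoromethyl)phenyl on a carbon with a double bond to nitrogen. Among the compounds with values here, no measured pair isolates this change. Compound 1 carries the 3-(trifluoromethyl)phenyl group but differs from compound 3 in a second place as well; compound 1 gives 5.42 ug/mL and compound 3 gives 6.07 ug/mL, two numbers within the scatter of each other. Every change seen across these three compounds has left the number essentially unmoved, so no step beyond the scatter is expected here, a 1.0-fold lower number from compound 3 to compound 4 (0.02 log units; within the scatter), in either direction. Compound 4 is therefore estimated at 5.8 ug/mL, with a range from 3.5 ug/mL to 9.5 ug/mL.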

Compound 4, half-maximal inhibitory concentration: 6.52 ug/mL
Estimate against measurement, compound 4: 1.1-fold (0.05 log units) below, and the stated range covers the measured number.
By their numbers in this assay, from the lowest: compounds 1, 2, 3 and 4 (each within the scatter of the next).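

In this assay, the pair compound 3 and compound 4 isolates 3-(trifluoromethyl)phenyl in place of 4-(trifluoromethyl)phenyl on a carbon with a double bond to nitrogen, and it shows a 1.1-fold higher number from compound 3 to compound 4 (0.03 log units; within the scatter), so this change of the group has no readable effect. The same holds for 3-(trifluoromethyl)phenyl in place of 4-nitrophenyl at this carbon, with a 1.1-fold higher number from compound 2 to compound 4 (0.05 log units; within the scatter), and for 3,4-difluorophenyl in place of 4-nitrophenyl on a carbonyl carbon, with a 1.2-fold higher number from compound 1 to compound 4 (0.08 log units; within the scatter). No measurement shown here bears on this result.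

Going by these compounds alone, every group at this carbon so far is a phenyl carrying trifluoromethyl or nitro, and no step yet lies beyond the scatter. As far as these compounds go, what an amine or a carboxylic acid on that phenyl would do to the number remains open.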